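Aryl Swap on the Triazole of a Chalcone Series

The source may hold more compounds than are shown below. What is called first, only, known or untested is meant among the compounds shown, and "the series" means these compounds.

Compound 1 `COc1ccc(/C=C/C(=O)c2cccc(-n3cc(C(C)(C)O)nn3)c2)cc1O` gives 17100 nM in a functional assay on RAW264.7 cells (Mus musculus) for inhibition, with a stated time of 4 days; on this read-out lower numbers stand for stronger inhibition and higher numbers for weaker inhibition.
Compound 2 `COc1ccc(/C=C/C(=O)c2cccc(-n3cc(-c4cccc(Cl)c4)nn3)c2)cc1O` gives 6610 nM in this assay.

Of the compounds shown here, two have been measured so far. For the measured compounds named here, compound 2 holds the lowest of the two numbers; its nearest neighbour is compound 1, and the one step recorded between them, a 2.6-fold lower number from compound 1 to compound 2 (0.41 log units; beyond the scatter), is a modest one that lies beyond the scatter.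

Compound 3 `COc1ccc(/C=C/C(=O)c2cccc(-n3cc(-c4cc(F)cc(F)c4)nn3)c2)cc1O` is the next member of the series. It differs from compound 2 in a single place: 3,5-difluorophenyl in place of 3-chlorophenyl on an aromatic carbon. Going by the values given here, only one measured step exists in this set, a 2.6-fold lower number from compound 1 to compound 2 (0.41 log units; beyond the scatter), and it concerns the exchange of a 1-hydroxy-1-methylethyl for a 3-chlorophenyl rather than the exchange of one aryl for another. Among the compounds with values here, no measured step therefore bears directly on the move from a 3-chlorophenyl to a 3,5-difluorophenyl. Since both groups are six-membered aromatic rings of carbon only, carrying neither donors nor acceptors, the expected step of a 1.1-fold higher number from compound 2 to compound 3 (0.02 log units; within the scatter) is none beyond the scatter. Compound 3 is thus estimated to give about 7000 nM, within the range 3000 nM to 16000 nM.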

Compound 3, half-maximal inhibitory concentration: 7140 nM
Compound 3: the middle estimate sits 1.0-fold (0.01 log units) below what was measured; measured number inside the range.
By their numbers in this assay, from the lowest: compounds 2 and 3 (each within the scatter of the next); then compound 1.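

In this assay, replacing the 3-chlorophenyl with a 3,5-difluorophenyl on the aromatic carbon of the five-membered aromatic ring with 3 nitrogen gives a 1.1-fold higher number from compound 2 to compound 3 (0.03 log units; within the scatter), so this position does not distinguish between these two halogen-bearing aryl groups. For the compounds shown here, compound 1 and compound 2 alone offered only one aryl group at this position, whereas the step to the second aryl group, a 2.4-fold lower number from compound 1 to compound 3 (0.38 log units; beyond the scatter), shows that a lower number than with the 1-hydroxy-1-methylethyl is not confined to the 3-chlorophenyl. Nothing available here accounts for either step, or for the lack of separation between the two aryl groups.

The exchange removes chlorine and adds two fluorines at once, so the shared result does not show what each halogen contributes, and a 3-fluorophenyl or an unsubstituted phenyl would separate these contributions. On these data alone, it also remains open whether an aromatic ring of carbon only is needed here, or whether a pyridine ring, a cyclohexyl ring, or an aryl group bearing an amine or a carboxylic acid would fall with these two aryl compounds or with compound 1.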